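The source may report more compounds than this note shows. Statements on the series, on what has been measured and on what is new or still open speak of the compounds shown alone.

Compounds measured so far:
compound 1 `COc1ccc2c(=O)c(/C=C/C(=O)Nc3cccc(Cl)c3)coc2c1`; in a functional assay on Huh-7 cells (Homo sapiens) for inhibition, read by MTT assay, with a stated time of 48 h (a lower number here means a stronger inhibitor, a higher number a weaker inhibitor), compound 1 gives > 100000 nM, a limit of the assay.
compound 2 `COc1ccc(CNC(=O)/C=C/c2coc3cc(O)ccc3c2=O)cc1`; compound 2 gives 8430 nM.
compound 3 `COc1ccc2c(=O)c(/C=C/C(=O)NCc3ccccc3)coc2c1`; compound 3 gives 13600 nM.

Compound 3 stands highest of the two numbers, but compound 2 lies within the scatter of it, so no order between them is claimed. Compound 1 shows only a limit (the limit of > 100000 nM in this assay, at which 1 of the 3 values shown sits).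

Compound 4 `COc1cccc(NC(=O)/C=C/c2coc3cc(OC)ccc3c2=O)c1` differs from compound 3 by 3-methoxyphenyl in place of benzyl on an amide-type nitrogen. Going by the values given here, the one measured step that bears on this, an at least 7.3-fold lower number from compound 1 to compound 3 (0.86 log units; beyond the scatter), runs the other way: a substituted phenyl on the amide nitrogen gave a limit, benzyl gave a number. Returning a substituted phenyl to that nitrogen is therefore expected to raise the number in this assay by a 4.4-fold higher number from compound 3 to compound 4 (0.64 log units; beyond the scatter), quite possibly back to a limit. Compound 4 is estimated at 60000 nM, within 15000 nM to 100000 nM.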

Compound 4, half-maximal inhibitory concentration: 11100 nM
The estimate for compound 4 lay 5.4-fold (0.73 log units) above the measured number; the whole stated range lies above it.
By their numbers in this assay, from the lowest: compounds 2, 4 and 3 (each within the scatter of the next). At a limit, above all of these: compound 1.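

In this assay the change shows a 1.2-fold lower number from compound 3 to compound 4 (0.09 log units; within the scatter) and so does not separate 3-methoxyphenyl from benzyl on the amide-type nitrogen. A substituted phenyl on that nitrogen therefore does not by itself give a limit: there is an at least 9.0-fold lower number from compound 1 to compound 4 (0.95 log units; beyond the scatter) with methoxy in place of chloro on an aromatic carbon. Compound 1 stands at a limit, so the full size of that step stays open: the limit of > 100000 nM in this assay, at which 1 of the 4 values shown sits.

Still open, from the compounds shown here alone, is whether an amine or a carboxylic acid in place of methoxy on the aromatic carbon, or a longer chain in place of benzyl on the amide-type nitrogen, would shift the number beyond the scatter.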